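Notes on the step from compound 2 to compound 4

This account rests on a few compounds, and the source may have more. Where it says the series, first, only, none or still open, it means among the compounds named here.

Measured so far in a functional assay on SW-620 cells (Homo sapiens) for inhibition, read by MTT assay, with a stated time of 72 h; a lower number here means a stronger inhibitor, a higher number a weaker inhibitor:
- compound 1 `O=c1cc(Cn2cc(C3CC3)nn2)c2ccc(O)cc2o1`: in this assay compound 1 stops at a limit of the assay, > 100000 nM.
- compound 2 `O=c1cc(Cn2cc(CCCCl)nn2)c2ccc(O)cc2o1`: compound 2 gives 59800 nM.
- compound 3 `CCCCCCc1ccc(-c2cn(Cc3cc(=O)oc4cc(O)ccc34)nn2)cc1`: compound 3 gives 36800 nM.

Compound 2 holds the highest of the two numbers in this assay, and compound 3 sits nearest to it, within the scatter of repeated runs. The value of compound 1 is a limit only (the limit of > 100000 nM in this assay, at which 1 of the 3 values shown sits). Going by the values given here, the one measured step that touches this position, an at least 1.6-fold lower number from compound 1 to compound 2 (0.22 log units; that floor lies within the scatter), has a floor that lies inside the scatter and so gives no clear direction.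

Compound 4 `O=c1cc(Cn2cc(CSC(=S)N3CCNCC3)nn2)c2ccc(O)cc2o1` carries the change (a group of 9 heavy atoms (5 carbon, 2 nitrogen, 2 sulfur; one six-membered non-aromatic ring with 2 hetero atoms) in place of a group of 3 heavy atoms (2 carbon, 1 chlorine; no ring), on a saturated chain carbon bound to an aromatic carbon). No measured step swaps a chain of this kind for a ring-bearing group, so the only guide is the step from compound 1 to compound 2, which is small on the numbers shown. The expected step in this assay is therefore modest, with no preferred direction, and the estimate for compound 4 is 45000 nM, with a range from 12000 nM to 150000 nM. The estimated step is a 1.3-fold lower number from compound 2 to compound 4 (0.12 log units; within the scatter).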

Compound 4, half-maximal inhibitory concentration: > 100000 nM
Compound 4 gave a limit, no number (the forecaster's own chance of this, stated with the estimate: 30%); middle value at least 2.2-fold (0.34 log units) from the limit.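

In this assay compound 4 stops at a limit of the assay, > 100000 nM. Going by these compounds, putting the ring-bearing group in place of 2-chloroethyl, on a saturated chain carbon bound to an aromatic carbon, gives an at least 1.6-fold higher number from compound 2 to compound 4 (0.22 log units; that floor lies within the scatter); that floor gives no clear direction, and the real size of the step stays unknown, so the added hydrogen-bond donor and acceptors and the larger group come with no lower number to show for them. What is new is that a second substituent on the shared core, and the first one with its ring carried on a chain, now gives no number at all, so the upper end of the series is bounded only by the assay: the limit of > 100000 nM in this assay, at which 2 of the 4 values shown sit.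

The compounds shown leave open whether the ring, the two sulfur atoms or the overall size of the entering group goes with the limit in compound 4, as no pair here separates these features. Also open, on these data alone, is how a plain amine or a carboxylic acid on the same chain carbon would read in this assay, and whether a longer chain ending in chlorine would move the number from that of compound 2.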